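Aryl exchange on the shared core: notes toward compound 3

The source may hold more compounds than are shown below. What is called first, only, known or untested is meant among the compounds shown, and "the series" means these compounds.

Measured so far:
compound 1 `CCOC(=O)c1c(-c2ccc(C)cc2)c(C#N)c(=O)n(/N=C(\C)c2ccc(S(=O)(=O)N3CCCCC3)cc2)c1N` — 37900 nM
compound 2 `CCOC(=O)c1c(-c2ccc(O)c(OC)c2)c(C#N)c(=O)n(/N=C(\C)c2ccc(S(=O)(=O)N3CCCCC3)cc2)c1N` — 38700 nM

In a functional assay on MCF7 cells (Homo sapiens) for cytotoxicity, read by sulforhodamine B assay, with a stated time of 48 h (a higher number here means a weaker inhibitor, a lower number a stronger inhibitor), compound 1 gives 37900 nM and compound 2 gives 38700 nM. Compound 2 sits at the higher of the two numbers, but the step of a 1.0-fold higher number from compound 1 to compound 2 (0.01 log units; within the scatter) is within the scatter, so the two compounds cannot be separated on these data.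

Compound 3 `CCOC(=O)c1c(-c2ccc(Cl)cc2)c(C#N)c(=O)n(/N=C(\C)c2ccc(S(=O)(=O)N3CCCCC3)cc2)c1N` differs from compound 2 in one place: 4-chlorophenyl in place of 4-hydroxy-3-methoxyphenyl on an aromatic carbon. Among the compounds with values here, the only measured step that bears on this change is the aryl exchange at the same carbon, a 1.0-fold higher number from compound 1 to compound 2 (0.01 log units; within the scatter), which was flat. Within the data shown here, with one flat step as the sole guide, no change beyond the scatter is expected for compound 3 in this assay, so the estimated step is a 1.0-fold lower number from compound 2 to compound 3 (0.01 log units; within the scatter). Compound 3 is therefore estimated at 38000 nM, with a range from 15000 nM to 95000 nM.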

Compound 3, half-maximal inhibitory concentration: 20600 nM
For compound 3 the middle estimate is 1.8-fold (0.27 log units) above the measured one; the measured number falls inside the stated range.
By their numbers in this assay, from the lowest: compounds 3, 1 and 2 (each within the scatter of the next).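

In this assay the exchange of 4-hydroxy-3-methoxyphenyl for 4-chlorophenyl on this carbon is a 1.9-fold lower number from compound 2 to compound 3 (0.27 log units; within the scatter), and chloro in place of methyl is a 1.8-fold lower number from compound 1 to compound 3 (0.26 log units; within the scatter), so neither change separates the compounds. Three aryl groups at this position, opposite the ring nitrogen, now stand within the scatter of one another, even though the step from compound 2 to compound 3 exchanges a group with 1 hydrogen-bond donor and 2 hydrogen-bond acceptors for one with none of either. No measurement at hand offers an explanation for these steps.

On these data alone, whether any group on this carbon can move the number beyond the scatter stays open, for instance 4-aminophenyl or a phenyl ring carrying a carboxylic acid. The compounds shown also leave open how the series responds at other positions, such as a carboxylic acid in place of the ethoxycarbonyl group.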